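The source may hold more compounds than are shown below. What is called first, only, known or untested is meant among the compounds shown, and "the series" means these compounds.

The measured compounds:

Compound 1, `COc1ccc(Nc2nc(Oc3cccc(NC(=O)C=C(C)C)c3)c3sccc3n2)cc1`, gives 17600 nM in a functional assay on A-431 cells (Homo sapiens) for inhibition, read by MTT assay, with a stated time of 72 h; on this read-out lower numbers stand for stronger inhibition and higher numbers for weaker inhibition.
Compound 2, `COc1cccc(Nc2nc(Oc3cccc(NC(=O)C=C(C)C)c3)c3sccc3n2)c1`, gives 25800 nM in this assay.
Compound 3, `CC(C)=CC(=O)Nc1cccc(Oc2nc(Nc3cccc(C#N)c3)nc3ccsc23)c1`, gives 28300 nM in this assay.

Compound 3 carries the highest of the three numbers, but its gap to compound 2 and its gap to compound 1 both fall within the usual scatter, so the three compounds cannot be told apart on this assay. The steps among them change only the aryl group on the nitrogen: a 1.5-fold higher number from compound 1 to compound 2 (0.17 log units; within the scatter), a 1.6-fold higher number from compound 1 to compound 3 (0.21 log units; within the scatter) and a 1.1-fold higher number from compound 2 to compound 3 (0.04 log units; within the scatter), each within the scatter.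

Compound 4, `CCC/C=C/C(=O)Nc1cccc(Oc2nc(Nc3cccc(C#N)c3)nc3ccsc23)c1`, is not yet measured. It differs from compound 3 at the other end of the molecule: pent-1-en-1-yl in place of 2-methylprop-1-en-1-yl on a carbonyl carbon. Among the compounds with values here, none of the measured steps touches this carbonyl substituent, so there is no direct precedent for the change. What the three compounds do show is that this assay has so far been insensitive to the variations tried, all staying within the scatter. On that basis the expected step is small: a 1.0-fold lower number from compound 3 to compound 4 (0.00 log units; within the scatter), with no change expected beyond the scatter. Compound 4 is therefore estimated at 28000 nM in this assay, within a range of 9000 nM to 90000 nM.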

Compound 4, half-maximal inhibitory concentration: 20400 nM
Compound 4: middle estimate off by 1.4-fold (0.14 log units), on the high side; the range from low to high includes it.
By their numbers in this assay, from the lowest: compounds 1, 4, 2 and 3 (each within the scatter of the next).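

Replacing 2-methylprop-1-en-1-yl with pent-1-en-1-yl on the carbonyl carbon gives a 1.4-fold lower number from compound 3 to compound 4 (0.14 log units; within the scatter) in this assay, which is the only step shown at this end of the molecule, whereas the earlier steps all changed the aryl group on the nitrogen. So the insensitivity seen among compounds 1, 2 and 3 now extends to one change at this second position: the entering group has 5 heavy atoms against 4, both groups hold one double bond outside aromatic rings and no ring, and the two compounds cannot be told apart in this assay. Nothing shown here explains this result.

Going by these compounds, a single step with two closely related groups says little about how much this position tolerates, so it remains open whether a fully saturated butyl chain, a phenyl ring, an amine or a carboxylic acid on this carbonyl carbon would move the number beyond the scatter. On these data alone, it is also open whether pent-1-en-1-yl would behave the same way alongside the 4-methoxyphenyl or 3-methoxyphenyl group on the nitrogen.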